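This account rests on a few compounds, and the source may have more. Where it says the series, first, only, none or still open, it means among the compounds named here.

Measured so far:
compound 1 `COc1ccc(-c2cs/c(=N\NC(=O)c3ccc(O)cc3)n2-c2ccc(OC)cc2OC)cc1` — 3310 nM
compound 2 `Cc1ccc(-c2cs/c(=N\NC(=O)c3ccc(O)cc3)n2-c2c(C)cccc2C)cc1` — 1320 nM

In a functional assay on HOP-92 cells (Homo sapiens) for cytotoxicity, read by sulforhodamine B assay, with a stated time of 48 h (on this read-out lower numbers stand for stronger inhibition of growth and higher numbers for weaker inhibition of growth), compound 1 gives 3310 nM, the higher of the two numbers measured. Compound 2 gives 1320 nM, and the gap between the two lies beyond the usual scatter, so compound 1 is the weaker of the pair on this read-out. Compound 3 `COc1ccc(-n2c(-c3ccc(Cl)cc3)cs/c2=N\NC(=O)c2ccc(O)cc2)c(OC)c1` keeps the core of compound 1 and differs from it in one place: chloro in place of methoxy on an aromatic carbon, sitting on an aromatic carbon of a six-membered aromatic ring of carbon only, para to a large group. Among the compounds with values here, no measured pair shows this single change, and compound 1 and compound 2 differ in several places at once, so nothing fixes its size or direction. In this assay the expected step is a 1.3-fold lower number from compound 1 to compound 3 (0.12 log units; within the scatter), small and in no clear direction beyond the scatter. Compound 3 is accordingly estimated at 2500 nM, with a range from 900 nM to 7000 nM.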

Compound 3, concentration for 50% growth inhibition: 14500 nM
Compound 3: the middle estimate sits 5.8-fold (0.76 log units) below what was measured; measured number above the stated range.
By their numbers in this assay, from the lowest: compound 2; then compound 1; then compound 3.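

In this assay, the series gains its first step with a single change: 4-methoxyphenyl to 4-chlorophenyl, on an aromatic carbon para to a large group, gives a 4.4-fold higher number from compound 1 to compound 3 (0.64 log units; beyond the scatter) and lies beyond the scatter. This position is therefore not indifferent to its substituent, and in this pair methoxy goes with stronger inhibition of growth than chloro. No measured property in hand bears on the reason for this step.

This single pair does not show whether the same change would run the same way on the rest of the series, including the core of compound 2. From the compounds shown here alone, whether an amine, a nitrile or a longer alkoxy chain at this position would restore or exceed the growth inhibition of compound 1 remains open.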